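Two Benzamides Measured, a Third Awaiting Its Number

This account rests on a few compounds, and the source may have more. Where it says the series, first, only, none or still open, it means among the compounds named here.

Compound 1 `Cc1ccccc1NS(=O)(=O)c1ccc(NC(=O)c2ccc(Cl)cc2Cl)cc1` gives 1230 nM in a functional assay on HEK293 cells for agonist activity at probable G-protein coupled receptor 27 (Homo sapiens), read by a luciferase reporter and beta-arrestin recruitment, with a stated time of 10 min; a lower number here means that less compound is needed, a higher number that more compound is needed for the effect.
Compound 2 `O=C(Nc1ccc(S(=O)(=O)Nc2ccccc2)cc1)c1ccc(Cl)cc1Br` gives 1020 nM in this assay.

Compound 2 holds the lowest of the two numbers, but its nearest neighbour, compound 1, lies within the scatter of it, so the two cannot be set in order. Compound 3 `O=C(Nc1ccc(S(=O)(=O)Nc2ccccc2)cc1)c1cc(F)c(Cl)cc1F` has not yet been measured. It differs from compound 2 in one place: 4-chloro-2,5-difluorophenyl in place of 2-bromo-4-chlorophenyl on a carbonyl carbon. Going by the values given here, no step between measured compounds is known, so nothing shows how the shared core answers to a change on the carbonyl carbon. Compound 1 and compound 2 carry different groups at that position and give numbers within the scatter of each other, which gives some ground to expect that compound 3 also stays near them. The step of a 1.5-fold higher number from compound 2 to compound 3 (0.17 log units; within the scatter) is expected to be small, perhaps a slight rise, and may well fall within the scatter. Compound 3 is therefore estimated at 1500 nM, with a range from 600 nM to 4000 nM.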

Compound 3, half-maximal effective concentration: 141 nM
Compound 3: middle estimate off by 11-fold (1.03 log units), on the high side; the measured number lies below the stated range.
By their numbers in this assay, from the lowest: compound 3; then compounds 2 and 1 (each within the scatter of the next).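

Going by these compounds alone, this is the first step between measured compounds at this position, and it shows that the shared core does answer to a change on the carbonyl carbon: in this assay, 4-chloro-2,5-difluorophenyl in place of 2-bromo-4-chlorophenyl gives a 7.2-fold lower number from compound 2 to compound 3 (0.86 log units; beyond the scatter). The step is modest in size, yet it lies beyond the scatter, so compound 3 stands clearly apart from compound 2. Within the data shown here, the single change removes the bromine and brings in two fluorine atoms together, and nothing available accounts for the lower number.

The compounds shown leave open whether the lower number goes with the loss of the bromine, with the fluorine atoms, or with both. They also leave open how a methoxy group or a nitrile on this ring would fare in this assay.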